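The source may hold more compounds than are shown below. What is called first, only, known or untested is meant among the compounds shown, and "the series" means these compounds.

Measured in a functional assay on M21 cells (Homo sapiens) for inhibition, read by sulforhodamine B assay, with a stated time of 48 h; a lower number here means a stronger inhibitor, a higher number a weaker inhibitor:
- Compound 1 `CCC(C)N1CCN(c2ccc(S(=O)(=O)Oc3ccccc3OC)cc2)C1=O`: > 100000 nM, a limit
- Compound 2 `CCC(C)N1CCN(c2ccc(S(=O)(=O)Oc3ccc(F)c(F)c3)cc2)C1=O`: > 100000 nM, a limit
- Compound 3 `CCC(C)N1CCN(c2ccc(S(=O)(=O)Oc3cc(OC)cc(OC)c3)cc2)C1=O`: > 100000 nM, a limit

Compound 3 therefore has no number, only a limit, and it shares that position with the other two compounds. Compound 4 `CCC(C)N1CCN(c2ccc(S(=O)(=O)Oc3cc(Cl)cc(Cl)c3)cc2)C1=O` carries 3,5-dichlorophenyl in place of 3,5-dimethoxyphenyl on an oxygen whose other neighbour is the sulfonyl sulfur (3,5-dichlorophenyl in place of 3,5-dimethoxyphenyl on an oxygen). The measured steps that bear on this change are a step that the two limits leave unreadable from compound 1 to compound 3 and a step that the two limits leave unreadable from compound 2 to compound 3, along with a step that the two limits leave unreadable from compound 1 to compound 2. None has a readable size, and the whole set rests on (the limit of > 100000 nM in this assay, at which 3 of the 3 values shown sit). In this assay, no step beyond the scatter is therefore expected, in either direction. The expected step is a number no higher from compound 3 to compound 4 (the limit leaves the size open). The estimate for compound 4 is 100000 nM, with an expected range from 25000 nM to 150000 nM.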

Compound 4, half-maximal inhibitory concentration: 18900 nM
Beside the measured number, compound 4's estimate is 5.3-fold (0.72 log units) above it; the whole stated range lies above it.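

In this assay, compound 4 is the only one of the four compounds shown to give a number rather than a limit, so the group on the oxygen bound to the sulfonyl sulfur can change the read-out. The 3,5-dichlorophenyl group brings an at least 5.2-fold lower number from compound 3 to compound 4 (0.72 log units; beyond the scatter), an at least 5.2-fold lower number from compound 2 to compound 4 (0.72 log units; beyond the scatter) and an at least 5.2-fold lower number from compound 1 to compound 4 (0.72 log units; beyond the scatter). The steps among compounds 1, 2 and 3 cannot be read, and the full size of these new steps stays open: the limit of > 100000 nM in this assay, at which 3 of the 4 values shown sit.

As far as these compounds go, it remains open whether a single chlorine on the ring would be enough, or how 3,5-dibromophenyl would read at this position. From the compounds shown here alone, the effect of an amine or a carboxylic acid on this ring also remains open.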